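Flavone ethers in a gastric-cancer cytotoxicity series

This account rests on a few compounds, and the source may have more. Where it says the series, first, only, none or still open, it means among the compounds named here.

Measured so far:
- compound 1, `COc1cc(OC)c2c(=O)c(OCC(=O)N/N=C/c3sccc3C)c(-c3cc(OC)c(OC)c(OC)c3)oc2c1`: in a functional assay on SGC-7901 cells (Homo sapiens) for cytotoxicity, read by MTT assay, with a stated time of 38 h (a lower number here means a stronger inhibitor, a higher number a weaker inhibitor), compound 1 gives 10300 nM
- compound 2, `COc1cc(OC)c2c(=O)c(OCCCCN3CCCCC3)c(-c3cc(OC)c(OC)c(OC)c3)oc2c1`: in this assay compound 2 gives 6080 nM

Within the data shown here, compound 1 has the highest of the two numbers recorded in this assay; its only neighbour is compound 2, and the one measured step, a 1.7-fold lower number from compound 1 to compound 2 (0.23 log units; within the scatter), does not rise above the scatter. The two measured compounds therefore read alike in this assay.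

Compound 3, `COc1cc(OC)c2c(=O)c(OCC(=O)N/N=C/c3ccccn3)c(-c3cc(OC)c(OC)c(OC)c3)oc2c1`, keeps the shared core of compound 1 and the whole chain that hangs from its aromatic oxygen; the change is pyridin-2-yl in place of 3-methylthiophen-2-yl on a carbon with a double bond to nitrogen. One aromatic ring of six heavy atoms with one hetero atom stands in for another of five.

Among the measured compounds shown here, no measured step touches this part of the molecule: the step from compound 1 to compound 2 swaps the entire chain, so it speaks only indirectly, and what it shows is that a larger change than this one left the number within the scatter. The expectation for compound 3 is accordingly a step of a 1.0-fold lower number from compound 1 to compound 3 (0.01 log units; within the scatter) in this assay, that is, nothing beyond the scatter in either direction. Compound 3 is estimated at 10000 nM, with a range from 4000 nM to 25000 nM.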

Compound 3, half-maximal inhibitory concentration: 16200 nM
Compound 3: middle estimate off by 1.6-fold (0.21 log units), on the low side; low and high end bracket the measured number.
By their numbers in this assay, from the lowest: compounds 2, 1 and 3 (each within the scatter of the next, the first and the last beyond it).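

In this assay, the first change measured on the carbon with a double bond to nitrogen, pyridin-2-yl in place of 3-methylthiophen-2-yl, stays within the scatter (a 1.6-fold higher number from compound 1 to compound 3 (0.20 log units; within the scatter)), so these two end groups read alike here. The whole-chain exchange now yields a step beyond the scatter, though only a modest one (a 2.7-fold higher number from compound 2 to compound 3 (0.43 log units; beyond the scatter)), whereas the same exchange made from compound 1 did not; among these three compounds, only the pair with the pyridin-2-yl end separates. No measurement on hand offers an explanation for either step.

Whether any group on this carbon can move the number clearly beyond the scatter remains open, since only two aromatic rings are shown there; a phenyl ring carrying a carboxylic acid or an amine would extend that comparison. Also open, going by these compounds, is how much of the step to compound 2 belongs to the six-membered non-aromatic ring and how much to the chain that carries it, which a shorter or longer chain ending in the same ring would begin to separate.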